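The source may report more compounds than this note shows. Statements on the series, on what has been measured and on what is new or still open speak of the compounds shown alone.

Measured compounds:
Compound 1 `CCCCC(O)c1cccc(NC(=O)NC(=O)CCl)c1`, 5700 nM in a functional assay on MCF7 cells (Homo sapiens) for antiproliferative activity, with a stated time of 48 h; a higher number here means a weaker inhibitor, a lower number a stronger inhibitor.
Compound 2 `CCCCC(OC)c1cccc(NC(=O)NC(=O)CCl)c1`, 6100 nM in this assay.

Among the measured compounds shown here, of the two measured compounds, compound 2 gives the higher number in this assay, yet its only neighbour is compound 1, and the one measured step, a 1.1-fold higher number from compound 1 to compound 2 (0.03 log units; within the scatter), lies within the scatter, so the two compounds cannot be placed in order.

Compound 3 `CCCCC(OC)c1cccc(NC(=O)CCCl)c1` has not been measured. It differs from compound 2 in one place: 2-chloroethyl in place of ((chloromethyl)carbonyl)amino on a carbonyl carbon. For the measured compounds named here, this change touches the chain on the nitrogen attached to the ring, a part of the molecule that none of the measured compounds vary. Going by the values given here, the one measured step concerns the oxygen on the saturated carbon and says nothing about this change. Among the compounds with values here, there is therefore no measured step that bears on the step from compound 2 to compound 3, and the expectation rests on the structural change alone, with a wide range. Compound 3 is estimated at 12000 nM in this assay, between 3000 nM and 50000 nM, which is an expected step of a 2.0-fold higher number from compound 2 to compound 3 (0.29 log units; within the scatter) from compound 2.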

Compound 3, half-maximal inhibitory concentration: > 100000 nM
Compound 3: no number, only a limit; the forecaster's own chance of this, stated with the estimate: 25%; middle value at least 8.3-fold (0.92 log units) away from the limit.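

Among the compounds shown here, putting 2-chloroethyl in place of ((chloromethyl)carbonyl)amino on a carbonyl carbon gives an at least 16-fold higher number from compound 2 to compound 3 (1.21 log units; beyond the scatter) in this assay, so this is the first change whose effect can be read as larger than the scatter. The earlier step, made on an oxygen on a saturated carbon, could not separate compound 1 from compound 2, whereas this one shows that the number in this assay depends strongly on what is attached to this carbonyl carbon. The reading for compound 3 is a limit and not a number, so the step has a lower bound but no known size: the limit of > 100000 nM in this assay, at which 1 of the 3 values shown sits.

The change removes the amide-type nitrogen, a carbonyl and the chlorine-bearing ((chloromethyl)carbonyl)amino unit in one move, so the compounds shown do not tell which of these parts the number depends on. They also leave open whether a methyl in place of the chlorine, an amine on the carbonyl carbon, or a longer chain ending in chlorine would hold the number near that of compound 2.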